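Selenium-benzyl for methylsulfanyl on two acylated isothiourea cores

This account rests on a few compounds, and the source may have more. Where it says the series, first, only, none or still open, it means among the compounds named here.

The study compares four acyl-isothiourea compounds in a functional assay on K562 cells (Homo sapiens) for cytotoxicity, read by MTT assay, with a stated time of 72 h; a lower number here means a stronger inhibitor of growth, a higher number a weaker inhibitor of growth. Compound 1 `CS/C(=N\C(=O)c1ccco1)NC(=O)c1ccco1` carries two furoyl groups on the shared core; in this assay compound 1 gives 64800 nM. Compound 3 `CS/C(=N\C(=O)c1cc(-c2ccccc2)nc2ccccc12)NC(=O)c1cc(-c2ccccc2)nc2ccccc12` bears a different pair of acyl groups, and the difference between the two cores is not broken down here. In this assay compound 3 gives 34400 nM. Compound 2 `O=C(/N=C(/NC(=O)c1cc(-c2ccccc2)nc2ccccc12)[Se]Cc1ccccc1)c1cc(-c2ccccc2)nc2ccccc12` is related to compound 3 by a group of 8 heavy atoms (7 carbon, 1 selenium; one six-membered aromatic ring of carbon only) in place of a group of 2 heavy atoms (1 carbon, 1 sulfur; no ring), on a carbon with a double bond to nitrogen, and in this assay compound 2 gives 9060 nM. That change yields a 3.8-fold lower number from compound 3 to compound 2 (0.58 log units; beyond the scatter).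

Compound 4 `O=C(/N=C(/NC(=O)c1ccco1)[Se]Cc1ccccc1)c1ccco1` has not yet been measured. It stands to compound 1 as compound 2 stands to compound 3: the change is a group of 8 heavy atoms (7 carbon, 1 selenium; one six-membered aromatic ring of carbon only) in place of a group of 2 heavy atoms (1 carbon, 1 sulfur; no ring), on a carbon with a double bond to nitrogen, the same kind of change on the other core. Among the compounds with values here, the expectation for compound 4 rests on that single measured step, because the step of a 3.8-fold lower number from compound 3 to compound 2 (0.58 log units; beyond the scatter) is the only example of this change seen here. Compound 4 is therefore estimated to show a 3.6-fold lower number from compound 1 to compound 4 (0.56 log units; beyond the scatter). In this assay compound 4 is expected to give about 18000 nM, with a likely range from 7000 nM to 45000 nM.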

Compound 4, concentration for 50% growth inhibition: 9530 nM
For compound 4 the middle estimate is 1.9-fold (0.28 log units) above the measured one; low and high end bracket the measured number.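

In this assay the selenium-benzyl group in place of methylsulfanyl gives a 6.8-fold lower number from compound 1 to compound 4 (0.83 log units; beyond the scatter), and this step can be set against the one on the other core: the same change on two cores in this assay, a 3.8-fold lower number (0.58 log units; beyond the scatter) from compound 3 to compound 2 and a 6.8-fold lower number (0.83 log units; beyond the scatter) from compound 1 to compound 4, 1.8-fold (0.25 log units) apart, within the scatter of two such steps. The change therefore lowers the number on both cores shown, and the size of that drop cannot be told apart between them. This rests on just two matched pairs in a single assay, so it does not show that the change would carry to any further core, and it does not separate the part played by the selenium from that played by the benzyl ring, which enter together.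

The compounds shown leave open what either core would give with benzylsulfanyl, which keeps the benzyl on sulfur, or with methylselanyl, which keeps the methyl on selenium. They also leave open whether a longer chain on the selenium, or an amine in the same place, would give a similar step.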